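This account rests on a few compounds, and the source may have more. Where it says the series, first, only, none or still open, it means among the compounds named here.

Two compounds of the series have numbers in an in vitro assay on HEK ts201 cells for negative allosteric modulation of Neuronal acetylcholine receptor; alpha4/beta2 (Homo sapiens), read by fluorescence and calcium flux, with a stated time of 1.5 s; a higher number here means a weaker inhibitor, a lower number a stronger inhibitor. Compound 1 `O=C(CN1CCN(S(=O)(=O)c2ccc(F)cc2)CC1)Nc1ccccc1` gives 14900 nM, and compound 2 `O=C(CN1CCN(S(=O)(=O)c2ccccc2)CC1)Nc1ccccc1F` gives 4100 nM. Compound 2 holds the lowest number of the two, with compound 1 sitting higher, beyond the scatter. Compound 3 `O=C(CN1CCN(S(=O)(=O)c2ccccc2)CC1)Nc1ccccc1` is not yet measured; it differs from compound 2 by hydrogen in place of fluoro on an aromatic carbon. Going by the values given here, no measured pair isolates this change, so its size is open. The expected step is a 1.5-fold higher number from compound 2 to compound 3 (0.17 log units; within the scatter), toward a weaker inhibitor if it clears the scatter at all. Compound 3 is estimated at 6000 nM, within 2500 nM to 15000 nM.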

Compound 3, half-maximal inhibitory concentration: 9600 nM
Beside the measured number, compound 3's estimate is 1.6-fold (0.20 log units) below it; low and high end bracket the measured number.
By their numbers in this assay, from the lowest: compound 2; then compounds 3 and 1 (each within the scatter of the next).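

In this assay, going by these compounds alone, the change from 2-fluorophenyl to phenyl gives a 2.3-fold higher number from compound 2 to compound 3 (0.37 log units; beyond the scatter) and is the first single change to clear the scatter, with fluoro sitting on an aromatic carbon ortho to a large group. The same swap of fluoro for hydrogen at the fluorinated aromatic carbon of compound 1 gives a 1.6-fold lower number from compound 1 to compound 3 (0.19 log units; within the scatter) and does not clear it, so among these compounds the change registers only at the first place. No available data explain this difference.

From the compounds shown here alone, whether chloro, methyl or methoxy on that aromatic carbon would match fluoro remains open. So does the outcome of placing fluoro on both aromatic rings at once.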